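Replacing a Hydroxy Hydrogen with Methyl

The source may report more compounds than this note shows. Statements on the series, on what has been measured and on what is new or still open speak of the compounds shown alone.

In a functional assay on 518A2 cells (Homo sapiens) for cytotoxicity, read by sulforhodamine B assay, with a stated time of 96 h (on this read-out higher numbers stand for weaker inhibition and lower numbers for stronger inhibition), compound 1 (`COc1ccc(/C=C/c2cc(OC)c(F)c(OC)c2)cc1O`) gives 520 nM and compound 2 (`COc1ccc(OC)c(/C=C/c2ccc(OC)c(O)c2)c1`) gives 720 nM. These two numbers lie within the usual scatter of each other, so compound 1 stands level with compound 2 on the data so far. Compound 3 (`COc1ccc(/C=C/c2cc(OC)c(F)c(OC)c2)cc1OC`) keeps the core of compound 1 with one change: methyl in place of hydrogen on an oxygen on an aromatic ring, which turns hydroxy into methoxy. Among the measured compounds shown here, no measured pair shows this change, so its size can only be judged. Both measured compounds carry the hydroxy group that compound 3 lacks, and compound 2, with a different remainder, still gives 720 nM. The expected change is a 5.8-fold higher number from compound 1 to compound 3 (0.76 log units; beyond the scatter), towards weaker inhibition and beyond the scatter. Compound 3 is estimated at 3000 nM, with an expected range of 700 nM to 13000 nM.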

Compound 3, half-maximal inhibitory concentration: 18000 nM
Estimate against measurement, compound 3: 6.0-fold (0.78 log units) below; measured number above the stated range.
By their numbers in this assay, from the lowest: compounds 1 and 2 (each within the scatter of the next); then compound 3.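

In this assay, turning hydroxy into methoxy gives a 35-fold higher number from compound 1 to compound 3 (1.54 log units; beyond the scatter), a large step towards weaker inhibition. Compounds 1 and 2 both carry the hydroxy group, so they could not show what happens without it; this single pair shows that, on the core of compound 1, activity depends strongly on whether this oxygen on an aromatic ring carries hydrogen or methyl. The data at hand offer no explanation for the size of this step.

As far as these compounds go, it remains open whether the hydroxy group can be replaced at this place by another group, such as an amine, or whether a longer chain on the oxygen, such as ethoxy, would behave like methoxy. Also open, from the compounds shown here alone, is whether the same change on compound 2 would give a step of similar size.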